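Working notes: loss of one aromatic methoxy, compound 3 to 4

The source may report more compounds than this note shows. Statements on the series, on what has been measured and on what is new or still open speak of the compounds shown alone.

compound 1 `C=CC[C@H]1C[C@]2([C@@H](C)Cc3ccc(OC)c(OC)c3)OCOC2=CC1=O`: 110 nM
compound 2 `C=CC[C@H]1C[C@]2(C(C)Cc3ccc(OC)c(OC(C)=O)c3)OCOC2=CC1=O`: 16 nM
compound 3 `C=CC[C@H]1C[C@]2([C@@H](C)Cc3cc(OC)c(OC)cc3F)OCOC2=CC1=O`: 14 nM

In a functional assay on M14 cells (Homo sapiens) for antiproliferative activity, with a stated time of 72 h (on this read-out higher numbers stand for weaker inhibition and lower numbers for stronger inhibition), compound 3 gives 14 nM, the lowest number of the three; its gap to compound 2 is within the scatter, its gap to compound 1 is beyond it. Within the data shown here, the only single-point step measured is a 7.9-fold lower number from compound 1 to compound 3 (0.90 log units; beyond the scatter), a change of fluoro for hydrogen. Compound 4 `C=CC[C@H]1C[C@]2([C@@H](C)Cc3ccc(OC)cc3F)OCOC2=CC1=O` differs from compound 3 by hydrogen in place of methoxy on an aromatic carbon. Among the measured compounds shown here, no measured step removes a methoxy, so the fluoro step gives no direct guide to this change. A modest weakening is expected, a 2.9-fold higher number from compound 3 to compound 4 (0.46 log units; beyond the scatter), with wide uncertainty. Compound 4 is estimated at 40 nM, range 12 nM to 140 nM.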

Compound 4, half-maximal inhibitory concentration: 14 nM
The estimate for compound 4 lay 2.9-fold (0.46 log units) above the measured number; low and high end bracket the measured number.
By their numbers in this assay, from the lowest: compounds 3, 4 and 2 (each within the scatter of the next); then compound 1.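

In this assay the loss of the methoxy para to a fluoro group gives no change at the digits printed from compound 3 to compound 4 (within the scatter) and this marks the first read on this position, as the earlier step concerned only the fluoro group. With the fluoro group in place, this methoxy is therefore dispensable on this read-out. No available evidence bears on why the number holds.

Still open, on these data alone, is whether hydrogen can replace this methoxy equally well on a ring without the fluoro group. The compounds shown also leave open how an amine or a carboxylic acid at this position would compare with hydrogen.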